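Moving the fluorine on the saturated ring carbon of compound 2

The source may report more compounds than this note shows. Statements on the series, on what has been measured and on what is new or still open speak of the compounds shown alone.

Measured so far:
compound 1 `COc1ccc(C2=NN(C(=O)c3ccc4c(c3)OCCO4)C(c3ccccc3F)C2)cc1` – 3470 nM
compound 2 `O=C(c1ccc2c(c1)OCCO2)N1N=C(c2ccccc2)CC1c1ccc(F)cc1` – 5210 nM
compound 3 `O=C(C1COc2ccccc2O1)N1N=C(c2ccccc2)CC1c1ccc(F)cc1` – 3270 nM

In a functional assay on WM 266-4 cells (Homo sapiens) for inhibition, read by MTT assay, with a stated time of 24 h (on this read-out higher numbers stand for weaker inhibition of growth and lower numbers for stronger inhibition of growth), compound 2 sits at the high end of the three numbers, yet its gap to compound 1 and its gap to compound 3 each lie within the scatter. Within the data shown here, the single measured step, a 1.6-fold lower number from compound 2 to compound 3 (0.20 log units; within the scatter), concerns the group on the carbonyl carbon and leaves the fluorophenyl untouched. Compound 4 `O=C(c1ccc2c(c1)OCCO2)N1N=C(c2ccccc2)CC1c1ccccc1F` differs from compound 2 as follows: 2-fluorophenyl in place of 4-fluorophenyl on a saturated ring carbon. Among the measured compounds shown here, no measured pair isolates this change; compound 1 also carries a 2-fluorophenyl on the saturated ring carbon, but it differs from compound 2 in a second place as well, so its value can only be noted. For the measured compounds named here, with no step bearing directly on the change, compound 4 is expected to show a step of a 1.2-fold lower number from compound 2 to compound 4 (0.06 log units; within the scatter), not beyond the scatter. Compound 4 is therefore estimated at 4500 nM in this assay, within 2200 nM to 9500 nM.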

Compound 4, concentration for 50% growth inhibition: 2500 nM
Compound 4: middle estimate off by 1.8-fold (0.26 log units), on the high side; low and high end bracket the measured number.
By their numbers in this assay, from the lowest: compounds 4, 3, 1 and 2 (each within the scatter of the next, the first and the last beyond it).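

In this assay, among these compounds, moving the fluorine on the saturated ring carbon, with 2-fluorophenyl in place of 4-fluorophenyl, gives the first step beyond the scatter in this set, a 2.1-fold lower number from compound 2 to compound 4 (0.32 log units; beyond the scatter), though a modest one. The phenyl on this carbon therefore responds to where its fluorine stands, even though the group that leaves and the group that enters have the same atoms. With the 2-fluorophenyl in place, hydrogen in place of methoxy on an aromatic carbon gives a 1.4-fold lower number from compound 1 to compound 4 (0.14 log units; within the scatter), so this change cannot be read as a difference, and no measurement offered here accounts for the fluorine step.

From the compounds shown here alone, it remains open whether a chlorine, an amine or a carboxylic acid in place of the fluorine would give a similar number. Also open, going by these compounds, is whether the 2-fluorophenyl would give a comparable step alongside the 2,3-dihydro-1,4-benzodioxin-2-yl group of compound 3.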